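The compounds below may be only part of what the source reports. "The series", "measured", "known", "first", "only" and "open" are said of these compounds alone.

Measured so far in an assay for inhibition of Tryptophan 2,3-dioxygenase (Homo sapiens), with stated times of 10 min and 60 min, tested at 100 uM; on this read-out higher numbers stand for a stronger effect at the one concentration tested and lower numbers for a weaker effect:
compound 1, `O=[N+]([O-])c1cccc(CNc2cc(C(F)(F)F)cc3[nH]ncc23)c1`: 82%
compound 2, `FC(F)(F)c1cc(NCC2CNC2)c2cn[nH]c2c1`: 49%
compound 3, `OC1CCCC(Nc2cccc(CNc3cc(C(F)(F)F)cc4[nH]ncc34)c2)C1`: 23%

Compound 3 stands lowest of the three numbers. Nearest to it is compound 2, higher by a gap beyond the scatter; furthest is compound 1, higher by a gap also beyond the scatter. Among the measured compounds shown here, the one measured step is a number 59 percentage points lower from compound 1 to compound 3 (beyond the scatter), a large fall when (3-hydroxycyclohexyl)amino took the place of nitro on an aromatic carbon.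

Compound 4, `FC(F)(F)c1cc(NCc2cccc(Br)c2)c2cn[nH]c2c1`, is still to be measured in this assay. It differs from compound 3 thus: bromo in place of (3-hydroxycyclohexyl)amino on an aromatic carbon. The step from compound 1 to compound 3 bears on it directly, running the other way: a small group gave way to the large one and the number fell hard. Compound 4 puts a small group back on that aromatic carbon, so a rise beyond the scatter is expected, though bromo is not nitro and compound 1 alone cannot fix how far the recovery goes. The expected step is a number 42 percentage points higher from compound 3 to compound 4 (beyond the scatter). For compound 4 the estimate is 65%, between 40% and 85%.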

Compound 4, a percentage reported as inhibition, at one concentration (the size of the read-out at that concentration, not a potency): 84%
The estimate for compound 4 lay 19 percentage points below the measured number, and the stated range covers the measured number.
By their numbers in this assay, from the lowest: compound 3; then compound 2; then compounds 1 and 4 (each within the scatter of the next).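

In this assay the change to bromo gives a number 61 percentage points higher from compound 3 to compound 4 (beyond the scatter) and so reverses the fall that came with (3-hydroxycyclohexyl)amino on this aromatic carbon. Bromo and nitro are not told apart at this place, with a number 2 percentage points higher from compound 1 to compound 4 (within the scatter) as the step between them. With the bromo group kept, the side chain also matters, as 3-bromophenyl in place of azetidin-3-yl gives a number 35 percentage points higher from compound 2 to compound 4 (beyond the scatter) for that change.

Whether a chloro group, a plain hydrogen or a simple amine on this aromatic carbon would hold the number at the level of the bromo and nitro compounds remains open from the compounds shown. No measured evidence at hand bears on the reason for these steps.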